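Working notes on a small cytotoxicity series and a fourth compound

The source may report more compounds than this note shows. Statements on the series, on what has been measured and on what is new or still open speak of the compounds shown alone.

Compound 1 `COc1cc(-c2cc(/C=C/C(=O)c3ccc(N)cc3)[nH]n2)cc(OC)c1OC`, compound 2 `COc1ccc(-c2cc(/C=C/C(=O)c3ccc(OC)c(OC)c3)[nH]n2)cc1` and compound 3 `COc1ccc(-c2cc(/C=C/C(=O)c3cc(OC)c(OC)c(OC)c3)[nH]n2)cc1OC` share one core. In a functional assay on Malme-3M cells (Homo sapiens) for cytotoxicity, read by sulforhodamine B assay, with a stated time of 48 h, tested at 0.01 uM (a lower number here means a stronger effect, a higher number a weaker effect of the compound at the concentration tested), compound 1 gives 98%, level at the digits shown with compound 3, which gives 98%, together the highest of the three numbers and the nearest pair, with no change between them within the scatter. Compound 2 gives 89%, the furthest from compound 1, a gap still within the scatter. Compound 4 `COc1cc(-c2cc(/C=C/C(=O)c3ccc(F)c(F)c3)[nH]n2)cc(OC)c1OC` differs from compound 1 by 3,4-difluorophenyl in place of 4-aminophenyl on a carbonyl carbon. Within the data shown here, with no step between measured compounds known, the step expected for compound 4 is a number 3 percentage points lower from compound 1 to compound 4 (within the scatter), none beyond the scatter in either direction. Compound 4 is estimated at 95%, with a range from 82% to 105%.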

Compound 4, a percentage reported as activity, at one concentration (the size of the read-out at that concentration, not a potency): 93%
The estimate for compound 4 lay 2 percentage points above the measured number; the measured number falls inside the stated range.
By their numbers in this assay, from the lowest: compounds 2, 4, 1 and 3 (each within the scatter of the next).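

Among these compounds, compound 1 and compound 4 give the first pair that differs in one place: with 3,4-difluorophenyl in place of 4-aminophenyl on a carbonyl carbon, this assay shows a number 5 percentage points lower from compound 1 to compound 4 (within the scatter). At this position, then, a ring carrying fluorine and a ring carrying an amine cannot be told apart at the concentration tested. Nothing available explains the step or its size.

Still open, on these data alone, is whether another group at this position, such as a carboxylic acid or a pyridine ring, would give a step beyond the scatter. Also open, as far as these compounds go, is whether the two groups would separate at higher concentrations.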